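Lengthening the Chain on the Chromanone-Free Core

This account rests on a few compounds, and the source may have more. Where it says the series, first, only, none or still open, it means among the compounds named here.

Measured compounds:
Compound 1, `C#CCN(C)CCCCCCOc1ccc2c(c1)CCCC2=O`, gives 133 nM in an assay on BTI cells for inhibition of Amine oxidase [flavin-containing] B (Homo sapiens), read by fluorescence and Amplex Red, with a stated time of 15 min; a higher number here means a weaker inhibitor, a lower number a stronger inhibitor.
Compound 2, `C#CCN(C)CCCOc1ccc2c(c1)OCCC2=O`, gives 11400 nM in this assay.

Compound 2 stands at the highest of the two numbers, and compound 1, which differs from it in both its core and its chain, gives the lower value of 133 nM. The two values show a wide gap, well beyond the scatter. Compound 3, `C#CCN(C)CCCCOc1ccc2c(c1)OCCC2=O`, keeps the core of compound 2 and changes only the chain: (methyl(propargyl)amino)methyl in place of methyl(propargyl)amino on a saturated chain carbon, three bonds along the chain from an oxygen on an aromatic ring. Going by the values given here, no measured pair shows this exact step, so the expectation rests on the two values alone. Compound 1 with its longer chain and different core gives 133 nM, so a lower number is expected for compound 3, with the step from compound 2 to compound 3 estimated at a 4.6-fold lower number from compound 2 to compound 3 (0.66 log units; beyond the scatter). Compound 3 is expected to give 2500 nM, within a range from 500 nM to 9000 nM.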

Compound 3, half-maximal inhibitory concentration: 58.9 nM
Estimate against measurement, compound 3: 42-fold (1.63 log units) above; measured number outside the range, below it.
By their numbers in this assay, from the lowest: compound 3; then compound 1; then compound 2.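

In this assay, placing (methyl(propargyl)amino)methyl where methyl(propargyl)amino stood, on a saturated chain carbon, three bonds along the chain from an oxygen on an aromatic ring, gives a 190-fold lower number from compound 2 to compound 3 (2.29 log units; beyond the scatter) and counts as a large step. With the core held fixed, this shows that the chain alone can move the number a great deal, which compound 1 and compound 2 could not show, as they differ in both core and chain. Nothing available here explains why this change has so large an effect.

From the compounds shown here alone, whether 2-(methyl(propargyl)amino)ethyl in the same place would lower the number further remains open. Also open, going by these compounds, are how the two cores compare on a matched chain and whether a different amine end, such as dimethylamino, would hold the value.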